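Swapping the Aryl Group on a Fused Thiadiazine Core

The source may report more compounds than this note shows. Statements on the series, on what has been measured and on what is new or still open speak of the compounds shown alone.

Measured so far:
compound 1, `CS(=O)(=O)c1ccc(Cc2nnc3n2N=C(c2ccccc2)CS3)cc1`: 51%
compound 2, `Cc1ccc(C2=Nn3c(Cc4ccc(S(C)(=O)=O)cc4)nnc3SC2)cc1`: 1.26%

In a functional assay on HT-29 cells (Homo sapiens) for cytotoxicity, read by MTT assay, with a stated time of 48 h, tested at 25 uM (a higher number here means a stronger effect of the compound at the concentration tested, a lower number a weaker effect), compound 2 stands lowest of the two numbers, its nearest neighbour being compound 1, which gives 51%. Within the data shown here, the one measured step, a number 49.7 percentage points lower from compound 1 to compound 2 (beyond the scatter), shows that changing the aromatic ring hanging off the shared core can shift the read-out strongly.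

Compound 3, `CS(=O)(=O)c1ccc(Cc2nnc3n2N=C(c2ccc(O)c(C(N)=O)c2)CS3)cc1`, is not yet measured. It differs from compound 2 as follows: 3-carbamoyl-4-hydroxyphenyl in place of 4-methylphenyl on a carbon with a double bond to nitrogen

Among the measured compounds shown here, only the step from compound 1 to compound 2 bears on this change, and it was large, so a change of similar size, in either direction, would not be surprising. Because compound 1 gives 51% with an unsubstituted ring, a return toward the middle is expected, giving a number 18.7 percentage points higher from compound 2 to compound 3 (beyond the scatter) for compound 3. The estimate for compound 3 is 20%, ranging from 0% to 55%.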

Compound 3, a percentage reported as activity, at one concentration (the size of the read-out at that concentration, not a potency): 24.7%
Beside the measured number, compound 3's estimate is 4.7 percentage points below it; the measured number falls inside the stated range.
By their numbers in this assay, from the lowest: compound 2; then compound 3; then compound 1.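

In this assay, replacing the aryl group on the carbon with a double bond to nitrogen gives a number 23.4 percentage points higher from compound 2 to compound 3 (beyond the scatter), yet it also gives a number 26.3 percentage points lower from compound 1 to compound 3 (beyond the scatter). The position is therefore not limited to a phenyl ring with or without a methyl: a larger ring substituent pattern carrying hydrogen-bond donors and acceptors retains a read-out that falls between the two simpler aryl groups, while the plain phenyl of compound 1 remains the highest of the three. Nothing available explains this order.

Compound 3 carries its hydroxy and carbamoyl groups together, so the share of each in the result cannot be separated. Going by these compounds, how a carboxylic acid or an amine on the phenyl ring would compare also remains open.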